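Pyridinyl in place of hydrogen on the aryl-free core

A few compounds are considered here, and "the series" means these few. Any claim that something is new, unique, unknown or untested is made for them only; others in the source may bear on it.

Compound 2 `c1ccc2c(c1)CCC2c1ncc[nH]1` carries hydrogen at the aromatic carbon under study. In a functional assay on CHO cells for agonist activity at Alpha-1B adrenergic receptor (Homo sapiens), read by FLIPR and calcium flux (on this read-out higher numbers stand for an effect only at larger amounts of compound and lower numbers for an effect already at smaller amounts), compound 2 gives only a limit, > 10000 nM, and not a number. Compound 2 thus sits at the limit of > 10000 nM in this assay, at which 1 of the 2 values shown sits. Compound 1 `Cc1n[nH]cc1-c1cccc2c1CCC2c1ncc[nH]1`, with 3-methyl-1H-pyrazol-4-yl at that carbon, gives 902 nM in this assay. Among the compounds with values here, the only measured step touching this position is an at least 11-fold higher number from compound 1 to compound 2 (1.04 log units; beyond the scatter), a large move in the weaker direction once the aromatic substituent is removed. Compound 3 `c1cncc(-c2cccc3c2CCC3c2ncc[nH]2)c1` is derived from compound 2 by pyridin-3-yl in place of hydrogen on an aromatic carbon. Within the data shown here, this reverses the direction of the single measured step, although with a different ring, one without a hydrogen-bond donor, so the size is uncertain. Compound 3 is expected to show an at least 4.0-fold lower number from compound 2 to compound 3 (0.60 log units; beyond the scatter) in this assay, a move beyond the scatter toward lower numbers. Compound 3 is estimated at 2500 nM in this assay, within 600 nM to 10000 nM.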

Compound 3, half-maximal effective concentration: > 10000 nM
Compound 3: no number, only a limit; the forecaster's own chance of this, stated with the estimate: 30%; middle value at least 4.0-fold (0.60 log units) away from the limit.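

In this assay compound 3 gives > 10000 nM as a limit of the assay and not a number. Pyridin-3-yl in place of 3-methyl-1H-pyrazol-4-yl on this aromatic carbon gives an at least 11-fold higher number from compound 1 to compound 3 (1.04 log units; beyond the scatter) and so shows that a six-membered aromatic ring with one hetero atom at this carbon does not match the five-membered substituent of compound 1, while the step from compound 2 cannot be read. Compound 1 remains the only compound shown with a number, and the other two share one limit: the limit of > 10000 nM in this assay, at which 2 of the 3 values shown sit.

Still open, going by these compounds, is whether the methyl group or the pyrazole ring itself accounts for the reading of compound 1, a question that unsubstituted 1H-pyrazol-4-yl at this carbon would address. Also open, on these data alone, is how a non-ring group at this carbon, such as an aminomethyl group or a carboxylic acid, would read.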